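This account rests on a few compounds, and the source may have more. Where it says the series, first, only, none or still open, it means among the compounds named here.

Measured compounds:
Compound 1, `O=C(Nc1ccc2c(c1)B(O)OC2)c1ccccc1C(F)(F)F`, gives 4400 nM in a functional assay on PBMC cells (Homo sapiens) for inhibition, read by HTRF, with stated times of 15 min and 24 h; on this read-out lower numbers stand for stronger inhibition and higher numbers for weaker inhibition.
Compound 2, `O=C(Nc1ccc2c(c1)B(O)OC2)c1ccccc1F`, gives only a limit of the assay in this assay, > 10000 nM, which is the limit of > 10000 nM in this assay, at which 1 of the 3 values shown sits.
Compound 3, `O=C(Nc1ccc2c(c1)B(O)OC2)c1cc(C(F)(F)F)ccc1F`, likewise gives only a limit of the assay in this assay, > 100000 nM, which is the limit of > 100000 nM in this assay, at which 1 of the 3 values shown sits.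

All three share one core; they differ on the amide-bearing ring. From compound 2 to compound 1 the change is trifluoromethyl in place of fluoro on an aromatic carbon, and the step is an at least 2.2-fold lower number from compound 2 to compound 1 (0.35 log units; beyond the scatter). From compound 2 to compound 3 the change is trifluoromethyl in place of hydrogen on an aromatic carbon; with both values at limits, the step is a step that the two limits leave unreadable from compound 2 to compound 3. Compound 4, `O=C(Nc1ccc2c(c1)B(O)OC2)c1cc(C(F)(F)F)ccc1C(F)(F)F`, has not yet been measured in this assay. It arises from compound 3 by trifluoromethyl in place of fluoro on an aromatic carbon, the same kind of change as that from compound 2 to compound 1, though not the same: here the place is also para to a trifluoromethyl group (4 heavy atoms), which the earlier place lacks. With compound 3 at a limit, the step from it can be sized only loosely; beside the earlier step, a step of a number no higher from compound 3 to compound 4 (the limit leaves the size open) is expected. Compound 4 is therefore estimated at 100000 nM, between 30000 nM and 300000 nM, with a fair chance that only a limit is reported again.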

Compound 4, half-maximal inhibitory concentration: 3000 nM
The estimate for compound 4 lay 33-fold (1.52 log units) above the measured number; measured number outside the range, below it.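

In this assay, trifluoromethyl in place of fluoro on an aromatic carbon goes with a lower number on both cores, so the direction of the change carries across the two cores shown: the same change on two cores in this assay, an at least 2.2-fold lower number (0.35 log units; beyond the scatter) from compound 2 to compound 1 and an at least 33-fold lower number (1.52 log units; beyond the scatter) from compound 3 to compound 4; the limit leaves it open whether they differ On the second core the change gives an at least 33-fold lower number from compound 3 to compound 4 (1.52 log units; beyond the scatter). On these data alone, compound 2 and compound 3 stand only at limits of the assay, so the size of the change on each core remains open, and a larger effect on the second core cannot be claimed. The related replacement of hydrogen by trifluoromethyl on an aromatic carbon gives a 1.5-fold lower number from compound 1 to compound 4 (0.17 log units; within the scatter), which leaves compound 1 and compound 4 unseparated.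

The compounds shown leave open whether the change would carry to any further core, since only two pairs bear on it. They also leave open how an amine, a carboxylic acid or a longer chain on the amide-bearing ring would read out in this assay, since every substituent varied here is fluoro or trifluoromethyl.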